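This account rests on a few compounds, and the source may have more. Where it says the series, first, only, none or still open, it means among the compounds named here.

Measured so far in an assay on HEK293 cells for activation of Kir3.1/Kir3.2 (Homo sapiens), read by thallium flux; a higher number here means a larger maximal response, a lower number a smaller maximal response:

compound 1, `Cc1cc(NC(=O)Cn2nnc(-c3ccccc3F)n2)n(C2CCCCC2)n1`: 88%
compound 2, `Cc1cc(NC(=O)Cn2nnc(-c3cccc(F)n3)n2)n(C2CCCCC2)n1`: > 83%
compound 3, `COc1ccc(-c2nnn(CC(=O)Nc3cc(C)nn3C3CCCCC3)n2)cc1`: 90%

The value of compound 2 is a limit of this assay, not a number. Of the two numbers, compound 3 is the higher, but a number 2 percentage points higher from compound 1 to compound 3 (within the scatter) is within the scatter, so the two cannot be ranked. Compound 4 is `Cc1cc(NC(=O)Cn2nnc(-c3ccc(C(F)(F)F)cc3)n2)n(C2CCCCC2)n1`; it differs from compound 3 by trifluoromethyl in place of methoxy on an aromatic carbon. Going by the values given here, only one step at the same place is readable: a number 2 percentage points higher from compound 1 to compound 3 (within the scatter). a step that the limit leaves unreadable from compound 1 to compound 2 and a step that the limit leaves unreadable from compound 2 to compound 3 stay unreadable because of the limit of > 83% in this assay, at which 1 of the 3 values shown sits. Swapping this group has so far left this assay unchanged within the scatter, so no step beyond the scatter is expected: a number 2 percentage points lower from compound 3 to compound 4 (within the scatter). Compound 4 is estimated at 88%, between 78% and 98%.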

Compound 4, largest response reached (Emax), in percent of the reference or control that the assay uses: 94%
Beside the measured number, compound 4's estimate is 6 percentage points below it; low and high end bracket the measured number.
By their numbers in this assay, from the lowest: compounds 1, 3 and 4 (each within the scatter of the next).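

In this assay, trifluoromethyl in place of methoxy gives a number 4 percentage points higher from compound 3 to compound 4 (within the scatter), so a group with no hydrogen-bond acceptor and one with a hydrogen-bond acceptor read alike at this place. The change from 2-fluorophenyl to 4-(trifluoromethyl)phenyl gives a number 6 percentage points higher from compound 1 to compound 4 (within the scatter), which also shows no step beyond the scatter. The value of compound 2 is a limit, so the step from it to compound 4 cannot be read: the limit of > 83% in this assay, at which 1 of the 4 values shown sits.

From the compounds shown here alone, whether an amine or a carboxylic acid on this ring would give a step beyond the scatter remains open.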